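This account rests on a few compounds, and the source may have more. Where it says the series, first, only, none or still open, it means among the compounds named here.

Of the compounds shown here, two have been measured so far. In a functional assay on HCT-15 cells (Homo sapiens) for inhibition (on this read-out lower numbers stand for stronger inhibition and higher numbers for weaker inhibition), compound 1 (`CCOC(=O)Nc1nc(=O)n(C2O[C@H](C(=O)O)[C@@H](O)[C@H]2O)cc1F`) gives 0.47 ug/mL as its value. Compound 2 (`CCCCCOC(=O)Nc1nc(=O)n(C2O[C@H](C(=O)O)[C@@H](O)[C@H]2O)cc1F`) gives 0.12 ug/mL in the same test and stands lowest of the two, which here means the stronger inhibition.

The next molecule, compound 3 (`C=CCOC(=O)Nc1nc(=O)n(C2O[C@H](C(=O)O)[C@@H](O)[C@H]2O)cc1F`), replaces the pentyl chain of compound 2 with allyl. This is vinyl in place of butyl on a saturated chain carbon bound to an oxygen next to a carbonyl group.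

For the measured compounds named here, only one measured step bears on this change. The modest 3.9-fold lower number from compound 1 to compound 2 (0.59 log units; beyond the scatter) came with propyl in place of hydrogen on the chain, and there the longer chain carried the lower number. Compound 3 gives up part of that added chain, so part of that gain is expected to be lost. Going by the values given here, no measured compound yet carries a double bond in this chain, so the expectation is loose. In this assay the expected change is a 2.3-fold higher number from compound 2 to compound 3 (0.37 log units; beyond the scatter) toward weaker inhibition, a modest step. For compound 3 the estimated value is 0.28 ug/mL with 0.12 ug/mL and 0.65 ug/mL as the expected ends of its range.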

Compound 3, half-maximal inhibitory concentration: 0.032 ug/mL
For compound 3 the middle estimate is 8.8-fold (0.94 log units) above the measured one, outside the stated range (below it).
By their numbers in this assay, from the lowest: compound 3; then compound 2; then compound 1.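

In this assay, the order of the numbers does not follow chain length: going from pentyl to the shorter allyl gives a 3.8-fold lower number from compound 2 to compound 3 (0.57 log units; beyond the scatter), so the trend seen between the ethyl chain of compound 1 and the pentyl chain of compound 2 does not extend to compound 3, which goes against it. Against the ethyl chain, the allyl chain gives a 15-fold lower number from compound 1 to compound 3 (1.17 log units; beyond the scatter), a large step that leaves compound 3 with the lowest number of the three, and here that means the strongest inhibition, so this place on the carbamate-like side chain tolerates more than a simple change in length would suggest. No measurement at hand gives a reason for this result.

Compound 3 differs from the other two in both chain size and its double bond, so these compounds cannot show which of the two matters; a saturated propyl chain in the same place would separate them. On these data alone, it also remains open how a benzyl group, a propargyl group or a chain longer than pentyl would compare with allyl here.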